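The compounds below may be only part of what the source reports. "The series", "measured", "known", "first", "only" and "open" are said of these compounds alone.

The measured compounds:
Compound 1, `Cc1ccc(C(=O)Nc2cccc(-c3oc4cc(-c5ccc(F)cc5)ccc4c(=O)c3O)c2)cc1`, in a functional assay on A549 cells (Homo sapiens) for antiproliferative activity, read by CCK-8 assay, with a stated time of 72 h (on this read-out lower numbers stand for stronger inhibition and higher numbers for weaker inhibition), gives 6910 nM.
Compound 2, `COc1ccccc1C(=O)Nc1cccc(-c2oc3cc(-c4ccc(F)cc4)ccc3c(=O)c2O)c1`, gives 11700 nM.
Compound 3, `O=C(Nc1cccc(-c2oc3cc(-c4ccc(F)cc4)ccc3c(=O)c2O)c1)c1ccc(C(F)(F)F)cc1`, gives 19400 nM.

Compound 3 has the highest number of the three. Its nearest neighbour is compound 2 (a 1.7-fold higher number from compound 2 to compound 3 (0.22 log units; within the scatter)), and compound 1 stands furthest off (a 2.8-fold higher number from compound 1 to compound 3 (0.45 log units; beyond the scatter)). The three compounds share one core and differ only in the aryl group on the carbonyl carbon of the amide.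

Compound 4, `COc1cccc(C(=O)Nc2cccc(-c3oc4cc(-c5ccc(F)cc5)ccc4c(=O)c3O)c2)c1`, has not yet been measured. It differs from compound 3 in one place: 3-methoxyphenyl in place of 4-(trifluoromethyl)phenyl on a carbonyl carbon. The step that bears most directly on this is the one in which a methoxyphenyl group was already set against the trifluoromethylphenyl group, a 1.7-fold higher number from compound 2 to compound 3 (0.22 log units; within the scatter), within the scatter. In the step of a 2.8-fold higher number from compound 1 to compound 3 (0.45 log units; beyond the scatter) the number rose modestly when the trifluoromethyl group entered. Compound 4 is therefore expected to give a somewhat lower number than compound 3. The expected step is a 1.8-fold lower number from compound 3 to compound 4 (0.25 log units; within the scatter), which may still lie within the scatter. The estimate for compound 4 is 11000 nM, with a range from 5000 nM to 25000 nM.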

Compound 4, half-maximal inhibitory concentration: 10800 nM
Compound 4: middle estimate off by 1.0-fold (0.01 log units), on the high side; the measured number falls inside the stated range.
By their numbers in this assay, from the lowest: compounds 1, 4, 2 and 3 (each within the scatter of the next, the first and the last beyond it).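

Placing 3-methoxyphenyl in place of 4-(trifluoromethyl)phenyl on this carbonyl carbon gives a 1.8-fold lower number from compound 3 to compound 4 (0.25 log units; within the scatter) and so stays inside the noise of this assay. The comparisons with the other two groups read the same way, with a 1.1-fold lower number from compound 2 to compound 4 (0.03 log units; within the scatter) against 2-methoxyphenyl and a 1.6-fold higher number from compound 1 to compound 4 (0.19 log units; within the scatter) against 4-methylphenyl, so the two methoxyphenyl groups cannot be told apart and compound 4 lies within the scatter of all three earlier compounds, although compound 1 and compound 3 lie beyond it from each other. No measurement shown offers an explanation for these numbers.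

Still open, on these data alone, is whether an aryl ring carrying an amine or a carboxylic acid on this carbonyl carbon would shift the number beyond the scatter. The same holds for a saturated alkyl chain in place of the aryl ring.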